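Adding a methoxy group to the ring of compound 3

The source may report more compounds than this note shows. Statements on the series, on what has been measured and on what is new or still open speak of the compounds shown alone.

Three compounds share a common core, and each has been tested in a functional assay on PC-3 cells (Homo sapiens) for inhibition, read by sulforhodamine B assay, with a stated time of 48 h; a lower number here means a stronger inhibitor of growth, a higher number a weaker inhibitor of growth. Compound 1, whose structure is `C=C(C)[C@@H]1CC=C(Cn2cc(COc3cccc(C4NC(=O)NC(C)=C4C(=O)OCC)c3)nn2)CC1`, gives a value in this assay that is only a limit of the measurement, > 100000 nM. Compound 2, with structure `C=C(C)[C@@H]1CC=C(Cn2cc(COc3ccc(C4NC(=O)NC(C)=C4C(C)=O)cc3OC)nn2)CC1`, gives 85700 nM in this assay. Compound 3, with structure `C=C(C)[C@@H]1CC=C(Cn2cc(COc3ccc(C4NC(=O)NC5=C4C(=O)CC(C)(C)C5)cc3)nn2)CC1`, gives 24000 nM in this assay, the lowest of the two numbers that were actually read; compound 2 sits at a higher number, and that gap lies beyond the usual scatter of repeated measurements. Compounds 1, 2 and 3 each differ from one another in more than one place, so none of these gaps can be tied to a single change.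

Compound 4, with structure `C=C(C)[C@@H]1CC=C(Cn2cc(COc3ccc(C4NC(=O)NC5=C4C(=O)CC(C)(C)C5)cc3OC)nn2)CC1`, has not yet been measured. It differs from compound 3 in one place: methoxy in place of hydrogen on an aromatic carbon, in words, methoxy in place of hydrogen on an aromatic carbon. Among the measured compounds shown here, no measured pair shows this exact change, so the expected step from compound 3 is small, in either direction or none beyond the scatter, a 1.2-fold lower number from compound 3 to compound 4 (0.08 log units; within the scatter). For compound 4 the estimated value in this assay is 20000 nM, with a likely range from 7000 nM to 60000 nM.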

Compound 4, concentration for total growth inhibition: > 100000 nM
Compound 4: only a limit was reported; the forecaster's own chance of this, stated with the estimate: 5%; middle value at least 5.0-fold (0.69 log units) from the limit.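

Methoxy in place of hydrogen on an aromatic carbon, ortho to a large group and meta to a large group, gives an at least 4.1-fold higher number from compound 3 to compound 4 (0.61 log units; beyond the scatter) in this assay. Among the compounds shown here, this is the first change that stands alone, as the earlier compounds each differ from one another in more than one place, and it shows that this one small addition, with the rest of the structure kept, is enough to weaken growth inhibition beyond the scatter. The value of compound 4, > 100000 nM, is a limit and not a number, so the step has a known minimum but no known full size, and the reading sits at the edge of what the assay reports: the limit of > 100000 nM in this assay, at which 2 of the 4 values shown sit.

The compounds shown leave open whether this weakening belongs to methoxy itself or would follow from other groups on the same carbon, such as hydroxyl, fluorine or the longer ethoxy. Going by these compounds, whether the same methoxy counts for as much on the core of compound 2 also stays open.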